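A few compounds are considered here, and "the series" means these few. Any claim that something is new, unique, unknown or untested is made for them only; others in the source may bear on it.

In a functional assay on A549 cells (Homo sapiens) for antiproliferative activity, read by sulforhodamine B assay, with a stated time of 72 h (on this read-out lower numbers stand for stronger inhibition of growth and higher numbers for weaker inhibition of growth), three closely related compounds have been examined. Compound 1 `CCc1cc(=O)c2ccc(OCC(C)C)c(CBr)c2o1` carries an isobutyl group on an oxygen on an aromatic ring, and in this assay compound 1 reaches only the limit > 29400 nM, which is not a number. Compound 2 `COc1ccc2c(=O)cc(C(C)Br)oc2c1CBr` likewise stops at the limit > 26500 nM. For the measured compounds named here, compound 3 `CC(C)Oc1ccc2c(=O)cc(C(C)Br)oc2c1CBr` is the single compound among the three with a measured number, giving 12800 nM in this assay, so it stands alone as the reference point. The step of an at least 2.0-fold lower number from compound 2 to compound 3 (0.31 log units; beyond the scatter) shows that enlarging the group on the oxygen brought the number down into the measurable range.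

Compound 4 `CC(C)COc1ccc2c(=O)cc(C(C)Br)oc2c1CBr` carries this change one step further: isobutyl in place of isopropyl on an oxygen on an aromatic ring. Going by the values given here, only one measured step bears on it, the change from methyl to isopropyl on that oxygen, and it was at least modest and beyond the scatter. Compound 1 also carries isobutyl on the oxygen, but it differs from compound 4 in a second place as well, so it offers no clean comparison. A further small lowering of the number, expected as a 1.6-fold lower number from compound 3 to compound 4 (0.20 log units; within the scatter), seems plausible but may not exceed the scatter. Compound 4 is therefore estimated at 8000 nM in this assay, with a likely range from 3000 nM to 25000 nM.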

Compound 4, concentration for 50% growth inhibition: 8710 nM
Compound 4: middle estimate off by 1.1-fold (0.04 log units), on the low side; measured number inside the range.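

In this assay, a 1.5-fold lower number from compound 3 to compound 4 (0.17 log units; within the scatter) shows that swapping isopropyl for isobutyl on this oxygen makes no change that can be told from ordinary repeat variation, so the clear gain seen on leaving methyl does not visibly carry on with this further carbon. The longer comparison, an at least 3.0-fold lower number from compound 2 to compound 4 (0.48 log units; beyond the scatter), shows that isobutyl, like isopropyl, stands clearly apart from methyl at this place, which suggests that among these three groups the main separation lies between methyl and the two branched groups. For the compounds shown here, a second place also comes into view for the first time: an at least 3.3-fold lower number from compound 1 to compound 4 (0.52 log units; beyond the scatter), a change that puts bromo in place of hydrogen on the saturated chain carbon bound to an aromatic carbon and a saturated chain carbon, with isobutoxy held constant.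

On these data alone, the full size of these two longer steps stays open, because compound 2 and compound 1 each stop at a limit of the assay and not at a number: the limit of > 26500 nM in this assay, at which 1 of the 4 values shown sits; (the limit of > 29400 nM in this assay, at which 1 of the 4 values shown sits). Also open, as far as these compounds go, is whether a longer chain, or a chain ending in an amine or a carboxylic acid, on this oxygen would shift the number beyond the scatter.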